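Isopropylcarbonyl in place of isopentyl on the shared core

The source may report more compounds than this note shows. Statements on the series, on what has been measured and on what is new or still open speak of the compounds shown alone.

Compounds measured in a functional assay on A549 cells (Homo sapiens) for cytotoxicity, with a stated time of 48 h (a higher number here means a weaker inhibitor, a lower number a stronger inhibitor), so far:
Compound 1 `CCCCCOc1ccc2oc(/C=C/[S+](C)[O-])cc(=O)c2c1` gives 1600 nM
Compound 2 `CC(C)COc1ccc2oc(/C=C/[S+](C)[O-])cc(=O)c2c1` gives 1100 nM
Compound 3 `CC(C)CCOc1ccc2oc(/C=C/[S+](C)[O-])cc(=O)c2c1` gives 1000 nM

In this assay compound 3 gives 1000 nM and stands within the scatter of both other compounds, as a 1.6-fold lower number from compound 1 to compound 3 (0.20 log units; within the scatter) and a 1.1-fold lower number from compound 2 to compound 3 (0.04 log units; within the scatter) show. The next compound is compound 4 `CC(C)C(=O)Oc1ccc2oc(/C=C/[S+](C)[O-])cc(=O)c2c1`, which keeps the shared core and differs at one place: isopropylcarbonyl in place of isopentyl on an oxygen on an aromatic ring. This puts isopropylcarbonyl in place of isopentyl on an oxygen on an aromatic ring. The measured steps bear on this change only loosely. Along with the two steps into compound 3, a 1.5-fold lower number from compound 1 to compound 2 (0.16 log units; within the scatter) alters only the saturated chain, and none of the three goes beyond the scatter. None of them brings in a carbonyl, so the data hold no direct measure of this change. The expected outcome is a 1.3-fold higher number from compound 3 to compound 4 (0.11 log units; within the scatter), with no step beyond the scatter foreseen and a wide margin kept on either side. For compound 4 the estimated value is 1300 nM, with an expected range from 500 nM to 3500 nM.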

Compound 4, half-maximal inhibitory concentration: 2400 nM
Estimate against measurement, compound 4: 1.8-fold (0.27 log units) below, within the range that was stated.
By their numbers in this assay, from the lowest: compounds 3, 2, 1 and 4 (each within the scatter of the next, the first and the last beyond it).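

In this assay, for the compounds shown here, this position on an oxygen on an aromatic ring moved the number beyond the scatter for the first time: the saturated chains had stayed within it, while isopropylcarbonyl brought a 2.4-fold higher number from compound 3 to compound 4 (0.38 log units; beyond the scatter) and a 2.2-fold higher number from compound 2 to compound 4 (0.34 log units; beyond the scatter) as its two modest steps. The separation is not uniform, since a 1.5-fold higher number from compound 1 to compound 4 (0.18 log units; within the scatter) stays within the scatter, so compound 1 goes against any general split between compound 4 and the saturated chains. Nothing measured here explains these steps.

Going by these compounds alone, whether the carbonyl itself accounts for them remains open, since compound 4 is the only compound here that carries one. Going by these compounds, it is also open whether a benzoyl group or a longer acyl chain on the same oxygen would track compound 4 or the saturated chains.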